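Working notes: dimethylamino step from compound 2 to compound 3

The source may report more compounds than this note shows. Statements on the series, on what has been measured and on what is new or still open speak of the compounds shown alone.

Measured so far:
compound 1, `O=C(O)Cc1sc(C(c2ccc(F)cc2)c2ccc(F)cc2)nc1-c1ccco1`, 80%
compound 2, `O=C(O)Cc1sc(C(c2ccc(F)cc2)c2ccc(F)cc2)nc1-c1ccncc1`, 80%

In an in vitro functional assay on HEK285-7 cells for antagonist activity at prostaglandin D2 receptor 2 (Homo sapiens), read by BRET and beta-arrestin recruitment (on this read-out higher numbers stand for larger maximal responses and lower numbers for smaller maximal responses), compound 1 gives 80%. In this assay compound 2 gives 80%. Among the measured compounds shown here, the one measured step, no change at the digits printed from compound 1 to compound 2 (within the scatter), exchanges the aryl group on the shared core and leaves the maximal response unchanged within the scatter; compound 2 therefore stands level with compound 1.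

Compound 3, `CN(C)c1cc(-c2nc(C(c3ccc(F)cc3)c3ccc(F)cc3)sc2CC(=O)O)ccn1`, differs from compound 2 as follows:
dimethylamino in place of hydrogen on an aromatic carbon
Cut one bond further out, the change reads pyridin-4-yl to 2-(dimethylamino)pyridin-4-yl.

For the measured compounds named here, no measured step adds a substituent to this ring; the only comparison available, from compound 1 to compound 2, shows the maximal response tolerating a swap of the whole aryl group. On that basis, for compound 3 the expected step in this assay is no change at the digits printed from compound 2 to compound 3 (within the scatter), none beyond the scatter. The estimate for compound 3 is 80%, expected between 62% and 96%.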

Compound 3, largest response reached (reported as efficacy), in percent of the reference or control that the assay uses: 80%
Beside the measured number, compound 3's estimate shows no gap at the digits printed; the range from low to high includes it.
By their numbers in this assay, from the lowest: compounds 1, 2 and 3 (each within the scatter of the next).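

In this assay, dimethylamino in place of hydrogen on an aromatic carbon, next to the ring nitrogen, gives no change at the digits printed from compound 2 to compound 3 (within the scatter), so this position of the pyridin-4-yl group carries a substituent with the maximal response held within the scatter. The step 2-(dimethylamino)pyridin-4-yl in place of furan-2-yl gives no change at the digits printed from compound 1 to compound 3 (within the scatter), which extends the earlier aryl exchange to a substituted ring. No supporting data bear on this result.

The compounds shown leave open whether a primary amine, a methoxy group or a morpholine in the same place keeps the maximal response level with these values. They also leave open how the response behaves with an amide in place of the carboxylic acid on the shared core.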